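A few compounds are considered here, and "the series" means these few. Any claim that something is new, unique, unknown or untested is made for them only; others in the source may bear on it.

Measured so far in an ADME assay on HEL cells (Homo sapiens) for cytotoxicity; on this read-out lower numbers stand for higher toxicity in this test and higher numbers for lower toxicity in this test:
Compound 1 `C/C(=N\NC(=O)COc1cccc2ccccc12)c1cccc([N+](=O)[O-])c1` gives 10.5 ug/mL.
Compound 2 `C/C(=N\NC(=O)COc1cccc2ccccc12)c1ccccc1` gives 20 ug/mL.
Compound 3 `C/C(=N\NC(=O)COc1cccc2ccccc12)c1ccccc1Br` gives 16.2 ug/mL.

Compound 3 stands second highest of these three numbers, with compound 2 nearest and compound 1 furthest: a 1.2-fold lower number from compound 2 to compound 3 (0.09 log units; within the scatter) and a 1.5-fold higher number from compound 1 to compound 3 (0.19 log units; within the scatter), both inside the scatter. Compound 4 `C/C(=N\NC(=O)COc1cccc2ccccc12)c1ccc([N+](=O)[O-])cc1` differs from compound 3 by 4-nitrophenyl in place of 2-bromophenyl on a carbon with a double bond to nitrogen. Among the compounds with values here, two measured steps bear on this. a 1.9-fold higher number from compound 1 to compound 2 (0.28 log units; within the scatter) shows what removing a nitro group did, and a 1.2-fold lower number from compound 2 to compound 3 (0.09 log units; within the scatter) shows what adding bromine did; each was small. Putting a nitro group back and taking bromine away is therefore expected to give at most a small shift toward lower numbers, not clearly beyond the scatter. The expected step is a 1.4-fold lower number from compound 3 to compound 4 (0.13 log units; within the scatter). Compound 4 is thus estimated at 12 ug/mL, within a range from 6 ug/mL to 24 ug/mL.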

Compound 4, half-maximal cytotoxic concentration: > 100 ug/mL
Compound 4 gave a limit, no number; the forecaster's own chance of this, stated with the estimate: 5%; middle value at least 8.3-fold (0.92 log units) away from the limit.
By their numbers in this assay, from the lowest: compounds 1, 3 and 2 (each within the scatter of the next). At a limit, above all of these: compound 4.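

In this assay, 4-nitrophenyl in place of 3-nitrophenyl gives an at least 9.5-fold higher number from compound 1 to compound 4 (0.97 log units; beyond the scatter), so the same group behaves very differently depending on where it sits on the ring. Nitro in place of hydrogen gives an at least 5.0-fold higher number from compound 2 to compound 4 (0.69 log units; beyond the scatter) and 4-nitrophenyl in place of 2-bromophenyl gives an at least 6.1-fold higher number from compound 3 to compound 4 (0.79 log units; beyond the scatter), whereas the earlier steps all stayed within the scatter. These sizes are only minimums, as compound 4 has a limit and not a number: the limit of > 100 ug/mL in this assay, at which 1 of the 4 values shown sits.

From the compounds shown here alone, it remains open how far compound 4 lies past its limit. Going by these compounds, it is also open whether an amine or a carboxylic acid in place of the nitro group would give a similarly high number.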